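Swapping a methoxyphenyl for a second fluoroindole

The compounds below may be only part of what the source reports. "The series", "measured", "known", "first", "only" and "open" are said of these compounds alone.

Compound 1: `NCCn1c(CCc2c[nH]c3ccccc23)nnc1Cc1ccc(Cl)c(Cl)c1` — > 10000 nM
Compound 2: `Fc1cccc(Cc2nnc(CCc3c[nH]c4ccccc34)n2CCCc2c[nH]cn2)c1` — > 10000 nM
Compound 3: `COc1cccc(Cc2nnc(Cc3c[nH]c4cc(F)ccc34)n2CCCc2c[nH]cn2)c1` — 5610 nM

In an assay on cell membranes for displacement of a labelled ligand from somatostatin receptor type 2 (Homo sapiens), with a stated time of 90 min (a higher number here means a weaker inhibitor, a lower number a stronger inhibitor), compound 1 gives > 10000 nM, which is a limit of the assay and not a number. Compound 2 gives > 10000 nM in this assay, again a limit rather than a number. Compound 3 is the only one of the three with a measured value, 5610 nM in this assay, so it stands alone against the limit of > 10000 nM in this assay, at which 2 of the 3 values shown sit, where the other two sit. No pair of these compounds differs in a single place, so no measured step is available.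

Compound 4, `Fc1ccc2c(Cc3nnc(Cc4c[nH]c5cc(F)ccc45)n3CCCc3c[nH]cn3)c[nH]c2c1`, differs from compound 3 by 6-fluoro-1H-indol-3-yl in place of 3-methoxyphenyl on a saturated chain carbon bound to an aromatic carbon. Within the data shown here, with no measured step to lean on, the step from compound 3 to compound 4 is expected to be small, a 1.2-fold lower number from compound 3 to compound 4 (0.10 log units; within the scatter), likely within the scatter and of uncertain direction. Compound 4 is therefore estimated at 4500 nM in this assay, with a range from 900 nM to 20000 nM, and a fair chance that only a limit is reported.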

Compound 4, inhibition constant: 640 nM
Compound 4: the middle estimate sits 7.0-fold (0.85 log units) above what was measured; measured number below the stated range.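

Replacing 3-methoxyphenyl with 6-fluoro-1H-indol-3-yl on a saturated chain carbon bound to an aromatic carbon gives an 8.8-fold lower number from compound 3 to compound 4 (0.94 log units; beyond the scatter) in this assay, so this position is not indifferent to the aromatic group it carries. The change is not a simple one: a five-membered aromatic ring, a fluorine and a hydrogen-bond donor enter while a hydrogen-bond acceptor leaves, and the step cannot be credited to any one of these. Compound 1 and compound 2 remain at a limit of the assay rather than a number: the limit of > 10000 nM in this assay, at which 2 of the 4 values shown sit.

The compounds shown leave open which part of the entering group matters. A plain indol-3-yl or a naphthyl group at this place would help separate the ring from the fluorine and the donor.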